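Aryl urea variation in the dimethyl/diethylamino triazole pyridyl ether series

The compounds below may be only part of what the source reports. "The series", "measured", "known", "first", "only" and "open" are said of these compounds alone.

Compound 1 `CN(C)CCn1cnnc1-c1cc(Oc2ccc(NC(=O)Nc3ccc(Cl)c(C(F)(F)F)c3)cc2F)ccn1` gives 880 nM in a functional assay on HT-29 cells (Homo sapiens) for antiproliferative activity, read by MTT assay, with a stated time of 72 h; a lower number here means a stronger inhibitor, a higher number a weaker inhibitor. Among the measured compounds shown here, compound 2 `CN(C)CCn1cnnc1-c1cc(Oc2ccc(NC(=O)Nc3ccccc3C(F)(F)F)cc2F)ccn1`, which carries 2-(trifluoromethyl)phenyl on the amide-type nitrogen instead, gives 5860 nM; the step of a 6.7-fold higher number from compound 1 to compound 2 (0.82 log units; beyond the scatter) is the only change of the aryl urea group measured so far. Compound 3 `CCN(CC)CCn1cnnc1-c1cc(Oc2ccc(NC(=O)Nc3ccc(Cl)c(C(F)(F)F)c3)cc2F)ccn1` gives 900 nM, and the step of a 1.0-fold higher number from compound 1 to compound 3 (0.01 log units; within the scatter) shows that compounds 1 and 3 sit within the scatter of each other; against compound 2, compound 3 shows the lower number of the two, by a gap beyond the scatter.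

Compound 4 `CCN(CC)CCn1cnnc1-c1cc(Oc2ccc(NC(=O)Nc3ccc(F)c(F)c3)cc2F)ccn1` differs from compound 3 only at the urea end: 3,4-difluorophenyl in place of 4-chloro-3-(trifluoromethyl)phenyl on an amide-type nitrogen. The step that bears on this is the aryl swap from compound 1 to compound 2, which moved the number upward by a modest amount, and the amine swap from compound 1 to compound 3 shows the diethylamino chain is a neutral background for such a comparison. No 3,4-difluorophenyl analogue has been measured, so the direction rests on one data point. A step toward a higher number is expected, estimated at a 3.3-fold higher number from compound 3 to compound 4 (0.52 log units; beyond the scatter).

Compound 4 is therefore expected to give about 3000 nM in this assay, within a range of 1000 nM to 10000 nM.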

Compound 4, half-maximal inhibitory concentration: 1240 nM
For compound 4 the middle estimate is 2.4-fold (0.38 log units) above the measured one; measured number inside the range.
By their numbers in this assay, from the lowest: compounds 1, 3 and 4 (each within the scatter of the next); then compound 2.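

In this assay, a 1.4-fold higher number from compound 3 to compound 4 (0.14 log units; within the scatter), so on the diethylamino chain, 3,4-difluorophenyl and 4-chloro-3-(trifluoromethyl)phenyl on the amide-type nitrogen cannot be told apart, even though the swap removes the chlorine and goes from 11 heavy atoms to 8. Among the compounds shown here, until now the only aryl change at this nitrogen was a 6.7-fold higher number from compound 1 to compound 2 (0.82 log units; beyond the scatter), which lies beyond the scatter and was made on the dimethylamino chain, so this position is now seen to tolerate at least one aryl replacement while responding to another. Nothing available here explains why these two aryl swaps differ in size.

As far as these compounds go, it remains open whether the 2-(trifluoromethyl)phenyl penalty carries over to the diethylamino chain and whether 3,4-difluorophenyl behaves the same way on the dimethylamino chain. Also open, from the compounds shown here alone, is how far this tolerance extends at the urea end, for example to unsubstituted phenyl or 4-methoxyphenyl, and whether a cyclic amine such as morpholine or pyrrolidine can replace the dialkylamino group on the chain.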